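This account rests on a few compounds, and the source may have more. Where it says the series, first, only, none or still open, it means among the compounds named here.

Measured so far in an assay (Rattus norvegicus) for inhibition of Fatty-acid amide hydrolase 1 (Homo sapiens); on this read-out higher numbers stand for weaker inhibition and lower numbers for stronger inhibition:
compound 1 `O=C(O)c1ccc(-c2cnc(C(=O)CCCCCCc3ccccc3)o2)cc1` gives 60 nM
compound 2 `O=C(CCCCCCc1ccccc1)c1ncc(-c2ccc(F)cc2)o1` gives 62 nM
compound 3 `O=C(CCCCCCc1ccccc1)c1ncc(-c2ccc(O)cc2)o1` gives 140 nM

Compound 3 stands at the highest of the three numbers: compound 2 is the nearest, and compound 1 the furthest, with the gap to each beyond the scatter. Compound 4 `NC(=O)c1ccc(-c2cnc(C(=O)CCCCCCc3ccccc3)o2)nc1` has not yet been measured. It differs from compound 3 in one place: 5-carbamoylpyridin-2-yl in place of 4-hydroxyphenyl on an aromatic carbon.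

Going by the values given here, two measured steps bear on this change, both ending at compound 3. The step of a 2.3-fold higher number from compound 1 to compound 3 (0.37 log units; beyond the scatter) shows that replacing carboxy with hydroxy weakens inhibition modestly, and the step of a 2.3-fold higher number from compound 2 to compound 3 (0.35 log units; beyond the scatter) shows the same size of loss when hydroxy replaces fluoro. Compound 4 removes the hydroxy and brings in a carbamoyl group on a ring that also carries a ring nitrogen. Among the compounds with values here, the carbamoyl resembles the carboxy of compound 1, but no measured pair speaks to the ring nitrogen, so the expectation rests on compound 1 alone. A modest return toward the number of compound 1 is therefore expected, with a 1.9-fold lower number from compound 3 to compound 4 (0.27 log units; within the scatter) as the estimated step. For compound 4 in this assay the estimated value is 75 nM, within a range from 30 nM to 200 nM.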

Compound 4, inhibition constant: 1.2 nM
Compound 4: middle estimate off by 63-fold (1.80 log units), on the high side, and the stated range ends above it.
By their numbers in this assay, from the lowest: compound 4; then compounds 1 and 2 (each within the scatter of the next); then compound 3.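

In this assay the change to 5-carbamoylpyridin-2-yl on this aromatic carbon is large from each earlier group: from 4-hydroxyphenyl it is a 120-fold lower number from compound 3 to compound 4 (2.07 log units; beyond the scatter) and from 4-fluorophenyl it is a 52-fold lower number from compound 2 to compound 4 (1.71 log units; beyond the scatter) and from 4-carboxyphenyl it is a 50-fold lower number from compound 1 to compound 4 (1.70 log units; beyond the scatter) as well. The earlier groups had differed only modestly or within the scatter, whereas this position now proves able to carry a far larger change, and compound 4 has the lowest number of the four, with all its steps beyond the scatter. No available evidence accounts for this gain.

Compound 4 brings in the ring nitrogen and the carbamoyl group together, so the compounds shown do not tell how the step divides between them. A carbamoylphenyl group, or a pyridine ring carrying a carboxylic acid or a nitrile instead, would separate the two.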